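Little Change Expected From Trimming a Long Chain

This account rests on a few compounds, and the source may have more. Where it says the series, first, only, none or still open, it means among the compounds named here.

In a functional assay on the whole organism (stomach) with Rattus norvegicus as the target (a lower number here means that less compound is needed, a higher number that more compound is needed for the effect), compound 2 `CCCCCCCCCC/N=C/N1CCC(C(c2ccccc2)c2ccccc2)CC1` gives 7.8 mg/kg and compound 1 `CCCCCC/N=C/N1CCC(C(c2ccccc2)c2ccccc2)CC1` gives 8.34 mg/kg so the two stand level within the usual scatter. Compound 3 `CCCCCCCC/N=C/N1CCC(C(c2ccccc2)c2ccccc2)CC1` is still unmeasured. It differs from compound 2 by hydrogen in place of ethyl on a saturated chain carbon, eight bonds along the chain from a double-bonded nitrogen in other words hydrogen in place of ethyl on a saturated chain carbon, eight bonds along the chain from a double-bonded nitrogen. Its chain is shorter than that of compound 2 and longer than that of compound 1. Within the data shown here, the one measured step that bears on this is a 1.1-fold lower number from compound 1 to compound 2 (0.03 log units; within the scatter) and it lies within the scatter, so no step beyond the scatter is expected in this assay here. The expected step is a 1.0-fold higher number from compound 2 to compound 3 (0.01 log units; within the scatter) and no more. Compound 3 is estimated at 8 mg/kg with 5 mg/kg to 13 mg/kg as its expected range.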

Compound 3, dose for half-maximal effect: 10.9 mg/kg
Compound 3: middle estimate off by 1.4-fold (0.13 log units), on the low side; the range from low to high includes it.
By their numbers in this assay, from the lowest: compounds 2, 1 and 3 (each within the scatter of the next).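

In this assay, hydrogen in place of ethyl on a saturated chain carbon, eight bonds along the chain from a double-bonded nitrogen, gives a 1.4-fold higher number from compound 2 to compound 3 (0.15 log units; within the scatter). Ethyl in place of hydrogen, six bonds along, gives a 1.3-fold higher number from compound 1 to compound 3 (0.12 log units; within the scatter), so the middle chain length stands level with both the shorter and the longer chain, and the two earlier compounds alone could not show this. Nothing at hand explains this result. The compounds shown leave open whether an amine or a carboxylic acid in place of this chain would also stand level.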